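A few compounds are considered here, and "the series" means these few. Any claim that something is new, unique, unknown or untested is made for them only; others in the source may bear on it.

Compound 1 `Cc1ccc(-c2nc(=O)o[nH]2)c(-c2ccc([C@@H](C)N(CC3CC3)c3nc(C(=O)NS(=O)(=O)C4CC4)c(C4CC4)s3)cc2)c1`: 5.4 h
Compound 2 `CONC(=O)c1ccc(Cl)cc1-c1ccc([C@@H](C)N(CC2CC2)c2nc(C(=O)NS(=O)(=O)C3CC3)c(C3CC3)s2)cc1`: 5.3 h

In an ADME assay on the whole organism (Macaca fascicularis), at a dose of 0.3 mg/kg by the oral route (on this read-out higher numbers stand for a longer-lived compound and lower numbers for a shorter-lived compound), compound 2 gives 5.3 h, and compound 1 gives 5.4 h, two numbers that lie within the scatter of each other, so neither stands apart. Compound 3 `CNC(=O)c1ccc(Cl)cc1-c1ccc([C@@H](C)N(CC2CC2)c2nc(C(=O)NS(=O)(=O)C3CC3)c(C3CC3)s2)cc1` differs from compound 2 by methyl in place of methoxy on an amide-type nitrogen. For the measured compounds named here, no measured pair shows this change, so no step size can be read from the numbers. A swap of this kind is expected to give no shift beyond the scatter in this assay, in either direction. The estimated change is a 1.1-fold lower number from compound 2 to compound 3 (0.03 log units; within the scatter). Compound 3 is expected to give 5 h, in the range 2.5 h to 10 h.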

Compound 3, mean residence time: 6.4 h
Compound 3: the middle estimate sits 1.3-fold (0.11 log units) below what was measured; the measured number falls inside the stated range.
By their numbers in this assay, from the lowest: compounds 2, 1 and 3 (each within the scatter of the next).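

In this assay, putting methyl in place of methoxy on the amide-type nitrogen gives a 1.2-fold higher number from compound 2 to compound 3 (0.08 log units; within the scatter), a step within the scatter. For the compounds shown here, this is the first direct view of this position: here, the methoxycarbamoyl and methylcarbamoyl groups cannot be told apart by this read-out. Nothing available offers a reason for this result.

Going by these compounds, it remains open whether an ethyl group on this nitrogen, or a carboxylic acid replacing the whole methylcarbamoyl group, would shift the mean residence time beyond the scatter.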